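Toward a smaller amide on the shared core

A few compounds are considered here, and "the series" means these few. Any claim that something is new, unique, unknown or untested is made for them only; others in the source may bear on it.

Measured so far in an assay on the whole organism (plasma, strain Sprague-Dawley) for inhibition of Dipeptidyl peptidase 4 (Rattus norvegicus), with a stated time of 6 h, at a dose of 1 mg/kg by the oral route; on this read-out lower numbers stand for less inhibition and higher numbers for more inhibition at the one dose given (going by the name of the read-out):
Compound 1 `CCN(CC)C(=O)[C@@H]1CN[C@H](C(=O)N2CCC[C@H]2C#N)C1`: 43%
Compound 2 `N#C[C@@H]1CCCN1C(=O)[C@@H]1C[C@H](C(=O)N2CCCCCC2)CN1`: 68%

Within the data shown here, compound 2 stands highest of the two measured numbers, and its only neighbour is compound 1, whose value lies lower by a step beyond the scatter. Among the measured compounds shown here, the one measured step, a number 25 percentage points higher from compound 1 to compound 2 (beyond the scatter), came with azepan-1-yl in place of diethylamino on a carbonyl carbon.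

Compound 3 `N#C[C@@H]1CCCN1C(=O)[C@@H]1C[C@H](C(N)=O)CN1` has not yet been measured in this assay. It differs from compound 2 as follows: amino in place of azepan-1-yl on a carbonyl carbon. For the measured compounds named here, the only step that bears on this change is the step from compound 1 to compound 2, which went up when the larger group entered on the carbonyl carbon. Compound 3 moves the opposite way and further, so a decrease in this assay is expected, of about a number 36 percentage points lower from compound 2 to compound 3 (beyond the scatter). Compound 3 is therefore estimated at 32%, within a range from 10% to 55%.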

Compound 3, a percentage reported as inhibition, in the whole organism at one dose (the size of the read-out at that dose, not a potency): 47%
The estimate for compound 3 lay 15 percentage points below the measured number, within the range that was stated.
By their numbers in this assay, from the lowest: compounds 1 and 3 (each within the scatter of the next); then compound 2.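

In this assay, amino in place of azepan-1-yl on a carbonyl carbon gives a number 21 percentage points lower from compound 2 to compound 3 (beyond the scatter), so the gain seen with azepan-1-yl does not survive when that group is reduced to amino. Amino in place of diethylamino gives a number 4 percentage points higher from compound 1 to compound 3 (within the scatter), so azepan-1-yl stands apart from both other groups, and the number does not simply climb with the size of the group: compound 1, with diethylamino, goes against such a trend. No available evidence explains why these groups differ at this position.

The compounds shown leave open whether a ring is what matters, since an open chain such as dipropylamino could be set against azepan-1-yl here. They also leave open whether a smaller ring, such as piperidin-1-yl or morpholin-4-yl, on the same carbonyl carbon would match compound 2.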